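Rearranged Dichlorophenyl and Cell Growth Inhibition

The source may report more compounds than this note shows. Statements on the series, on what has been measured and on what is new or still open speak of the compounds shown alone.

Measured so far:
compound 1, `O=C(/C=C/c1ccccc1Oc1ncnc2ccc(Cl)cc12)/C=C/c1cccc(Cl)c1Cl`, 76.5%
compound 2, `O=C(/C=C/c1ccccc1Oc1ncnc2ccc(Cl)cc12)/C=C/c1c(Cl)cccc1Cl`, 69.3%

Two compounds share one core and differ only in how two chlorines sit on the outer ring. In a functional assay on MGC-803 cells (Homo sapiens) for inhibition, read by MTT assay, with a stated time of 72 h, tested at 10 uM (a lower number here means less inhibition of growth, a higher number more inhibition of growth at the concentration tested), compound 1 gives 76.5%. In the same assay compound 2 gives 69.3%. Compound 2 holds the lower of the two numbers, yet the gap to compound 1, a number 7.2 percentage points lower from compound 1 to compound 2 (within the scatter), lies within the usual scatter of repeated measurements, so the two cannot be told apart on these data.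

Compound 3, `O=C(/C=C/c1ccc(Cl)c(Cl)c1)/C=C/c1ccccc1Oc1ncnc2ccc(Cl)cc12`, has the same atoms as compound 2 joined differently: 3,4-dichlorophenyl in place of 2,6-dichlorophenyl on a double-bonded chain carbon bound to a double-bonded chain carbon. Going by the values given here, the only measured step that bears on this, a number 7.2 percentage points lower from compound 1 to compound 2 (within the scatter), also moved the two chlorines on that ring and produced no change beyond the scatter. On that basis compound 3 is expected to inhibit growth about as much as compound 2, with a step of a number 2.7 percentage points higher from compound 2 to compound 3 (within the scatter). The estimate for compound 3 in this assay is 72%, with a range from 55% to 86%.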

Compound 3, percent growth inhibition at one concentration: 56.7%
Estimate against measurement, compound 3: 15.3 percentage points above; low and high end bracket the measured number.
By their numbers in this assay, from the lowest: compound 3; then compounds 2 and 1 (each within the scatter of the next).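

Until now, moving the two chlorines around the outer ring had produced no difference that could be told from the scatter, and the 3,4-dichlorophenyl group changes that picture. In this assay there is a number 12.6 percentage points lower from compound 2 to compound 3 (beyond the scatter) when it replaces 2,6-dichlorophenyl, and a number 19.8 percentage points lower from compound 1 to compound 3 (beyond the scatter) when it replaces 2,3-dichlorophenyl, so at this place, on a double-bonded chain carbon bound to a double-bonded chain carbon, the arrangement of the same atoms on the ring can matter even though the counted features of the groups stay identical. Nothing measured here accounts for the shift.

On these data alone, all three compounds keep two chlorines on this ring, so it remains open whether a single chlorine, or a methoxy group or an amine in its place, would hold growth inhibition at the level of compound 1. As far as these compounds go, the readings also come from one cell line at one concentration, so it remains open whether the gap between these arrangements would persist across a range of concentrations or in other cells.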